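Aryl-substituted ethers on the fluorinated bicyclic core

A few compounds are considered here, and "the series" means these few. Any claim that something is new, unique, unknown or untested is made for them only; others in the source may bear on it.

Compound 1 `CO[C@@H]1C[C@@H]2[C@H]([C@]1(N)C(=O)O)[C@@]2(F)C(=O)O` is the unsubstituted ether of the series. In an assay on CHO cells for binding affinity to metabotropic glutamate receptor 2 (Rattus norvegicus) (on this read-out lower numbers stand for stronger inhibition and higher numbers for weaker inhibition), compound 1 gives 39.2 nM, the highest of the three numbers recorded so far. Compound 2 `N[C@]1(C(=O)O)[C@H]2[C@@H](C[C@H]1OCc1ccccc1Cl)[C@]2(F)C(=O)O` carries a 2-chlorophenyl group on the ether carbon and in this assay compound 2 gives 4.99 nM; the change from compound 1 to compound 2 is a 7.9-fold lower number from compound 1 to compound 2 (0.90 log units; beyond the scatter). Compound 3 `N[C@]1(C(=O)O)[C@H]2[C@@H](C[C@H]1OCc1cccc(C(F)(F)F)c1)[C@]2(F)C(=O)O` carries a 3-(trifluoromethyl)phenyl group at the same position and in this assay compound 3 gives 5.72 nM, which, like the number for compound 2, lies well below that of compound 1.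

Compound 4 `Nc1cccc(CO[C@@H]2C[C@@H]3[C@H]([C@]2(N)C(=O)O)[C@@]3(F)C(=O)O)c1` has not yet been measured. It differs from compound 1 by 3-aminophenyl in place of hydrogen on a saturated chain carbon bound to an oxygen on a saturated carbon. Within the data shown here, the one step that bears on it directly is the one from compound 1 to compound 2, where adding an aryl group at this position lowered the number markedly, and compound 3 shows a similar drop with a different aryl group. The change in compound 4 is of the same kind, so a step in the same direction and of comparable size is expected, while the pair that is closest in substitution pattern is not itself measured.

The number for compound 4 in this assay is therefore estimated at 8 nM, with a range of 3 nM to 25 nM, corresponding to an expected step of a 4.9-fold lower number from compound 1 to compound 4 (0.69 log units; beyond the scatter).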

Compound 4, inhibition constant: 15.4 nM
Beside the measured number, compound 4's estimate is 1.9-fold (0.28 log units) below it, within the range that was stated.
By their numbers in this assay, from the lowest: compounds 2 and 3 (each within the scatter of the next); then compound 4; then compound 1.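

A third aryl group at this position again lowers the number in this assay, with a 2.5-fold lower number from compound 1 to compound 4 (0.41 log units; beyond the scatter), so the gain over the unsubstituted ether extends beyond the two aryl groups seen earlier. The aryl substituent also matters: amino in place of trifluoromethyl on an aromatic carbon gives a 2.7-fold higher number from compound 3 to compound 4 (0.43 log units; beyond the scatter), and the exchange of 2-chlorophenyl for 3-aminophenyl gives a 3.1-fold higher number from compound 2 to compound 4 (0.49 log units; beyond the scatter), both beyond the scatter, so an aryl group at this position does not by itself fix the number. Nothing available explains why compound 4 stands above compounds 2 and 3.

The compounds shown leave open whether a carboxylic acid or a methoxy group in place of the amino group would keep the number near that of compound 4 or bring it closer to that of compound 3. They also leave open how a longer chain at the saturated chain carbon bound to the oxygen would change the number for any of these aryl ethers.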